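A few compounds are considered here, and "the series" means these few. Any claim that something is new, unique, unknown or untested is made for them only; others in the source may bear on it.

Compound 1 `COc1ccc([N+](=O)[O-])cc1CSc1nc2cc(NC(=O)NC(C)(C)C)ccc2n1C1CC1`: 79 nM
Compound 2 `CCCCCn1c(SCc2cc([N+](=O)[O-])ccc2OC)nc2cc(NC(=O)NC(C)(C)C)ccc21`: 210 nM

Both compounds were tested in an assay on isolated protein for inhibition of Gonadotropin-releasing hormone receptor (Homo sapiens); a lower number here means a stronger inhibitor, a higher number a weaker inhibitor. Of the two numbers, compound 2 has the highest, with compound 1 the nearest: the step of a 2.7-fold higher number from compound 1 to compound 2 (0.42 log units; beyond the scatter) separates them.

Compound 3 `COc1ccc([N+](=O)[O-])cc1CSc1nc2cc(NC(=O)NC(C)(C)C)ccc2n1Cc1ccccc1` has not yet been measured in this assay. It differs from compound 2 in one place: phenyl in place of butyl on a saturated chain carbon bound to an aromatic nitrogen. For the measured compounds named here, the only measured step at the group on the aromatic nitrogen is a 2.7-fold higher number from compound 1 to compound 2 (0.42 log units; beyond the scatter), and that step concerns a different exchange, so no measured step covers phenyl in place of butyl directly. What that step does show is that a change at this position moves the number only modestly. A shift of about that size, in either direction, or none beyond the scatter, is what the data allow; the guess leans slightly toward a lower number. Compound 3 is therefore expected to give about 150 nM in this assay, within a range from 50 nM to 500 nM. This estimate corresponds to an expected step of a 1.4-fold lower number from compound 2 to compound 3 (0.15 log units; within the scatter).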

Compound 3, half-maximal inhibitory concentration: 28 nM
Estimate against measurement, compound 3: 5.4-fold (0.73 log units) above; the measured number lies below the stated range.
By their numbers in this assay, from the lowest: compound 3; then compound 1; then compound 2.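

In this assay, the group on the aromatic nitrogen turns out to matter more than the one earlier step suggested: phenyl in place of butyl on the saturated chain carbon, which is the same as benzyl in place of pentyl, gives a 7.5-fold lower number from compound 2 to compound 3 (0.88 log units; beyond the scatter) and is the largest step among these compounds. Benzyl also outperforms cyclopropyl, with a 2.8-fold lower number from compound 1 to compound 3 (0.45 log units; beyond the scatter), so compound 3 has the lowest number of the three, and its steps to both other compounds are beyond the scatter. This position can therefore do more than shift the number modestly upward, but nothing measured here explains why the benzyl group does better.

These compounds cannot show whether the gain depends on the aromatic ring itself or on that ring being held on the saturated chain carbon, a question that cyclohexylmethyl or phenyl attached directly to the aromatic nitrogen could help settle. As far as these compounds go, it also remains open how far the number would move with a longer link such as phenethyl, or with a fluorine or methoxy group on the benzyl ring.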